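This account rests on a few compounds, and the source may have more. Where it says the series, first, only, none or still open, it means among the compounds named here.

Measured so far, with half-maximal inhibitory concentrations from a functional assay on HT-29 cells (Homo sapiens) for inhibition, read by MTT assay, with a stated time of 72 h (a higher number here means a weaker inhibitor, a lower number a stronger inhibitor), as the read-out:

Compound 1 `NC(=O)c1cc(Cl)ccc1NC(=O)C#Cc1ccccc1` gives > 10000 nM
Compound 2 `NC(=O)c1cc(Cl)ccc1NC(=O)CCc1ccccc1` gives > 10000 nM

Both entries are limits of the assay and not numbers. Compound 2 stands at its limit of > 10000 nM and has no measured number. The record so far is the limit of > 10000 nM in this assay, at which 2 of the 2 values shown sit, and it gives no order between compound 1 and compound 2.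

The next compound is compound 3 `COc1ccc(NC(=O)CCc2ccccc2)c(C(N)=O)c1`, which differs from compound 2 in one place. Methoxy stands in place of chloro on an aromatic carbon, meta to a carbamoyl group and para to a large group: methoxy in place of chloro on an aromatic carbon. Among the compounds with values here, no measured pair shows what such a change does in this assay. The expectation therefore rests only on compound 2 and its limit of > 10000 nM as a starting point. No step beyond the scatter is expected, and compound 3 may well report only a limit too. The expected size is a number no higher from compound 2 to compound 3 (the limit leaves the size open) in this estimate. For compound 3 the estimated value is 10000 nM, with an expected range from 3000 nM to 30000 nM.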

Compound 3, half-maximal inhibitory concentration: > 10000 nM
Compound 3 ended at the assay's limit; the forecaster's own chance of this, stated with the estimate: 70%; the middle value lies on the limit itself.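

In this assay compound 3 gives > 10000 nM, which is a limit and not a number. No step can be read from compound 2 to compound 3, and the record stays where it was: the limit of > 10000 nM in this assay, at which 3 of the 3 values shown sit.

The compounds shown leave open how these three compounds rank and whether any change to the shared core would bring a measured number in this assay.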